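Shortening the amine chain on a nitrobenzofurazan ester

The source may report more compounds than this note shows. Statements on the series, on what has been measured and on what is new or still open speak of the compounds shown alone.

Measured compounds:
compound 1 `COc1ccccc1NC(=O)CCC(=O)OCCCCCCSc1ccc([N+](=O)[O-])c2nonc12` — 2850 nM
compound 2 `O=C(CCC(=O)OCCCCCCSc1ccc([N+](=O)[O-])c2nonc12)Nc1cccc(Cl)c1` — 1920 nM
compound 3 `CN(C)CCCNC(=O)CCC(=O)OCCCCCCSc1ccc([N+](=O)[O-])c2nonc12` — 1850 nM

All three compounds share a common core and differ only in the group carried on the amide-type nitrogen. In a functional assay on HOS cells (Homo sapiens) for inhibition, read by MTT assay, with a stated time of 72 h (on this read-out higher numbers stand for weaker inhibition and lower numbers for stronger inhibition), compound 1 gives 2850 nM, the highest of the three numbers, but its two neighbours lie close: a 1.5-fold lower number from compound 1 to compound 2 (0.17 log units; within the scatter) and a 1.5-fold lower number from compound 1 to compound 3 (0.19 log units; within the scatter). The two other compounds are likewise close to each other: a 1.0-fold lower number from compound 2 to compound 3 (0.02 log units; within the scatter). None of these steps rises above the scatter, so the three groups tried so far behave alike in this assay.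

Compound 4 `CN(C)CCNC(=O)CCC(=O)OCCCCCCSc1ccc([N+](=O)[O-])c2nonc12` is not yet measured. It differs from compound 1 as follows: 2-(dimethylamino)ethyl in place of 2-methoxyphenyl on an amide-type nitrogen. Within the data shown here, the nearest measured step is the one to compound 3, which carries the same kind of chain with the dimethylamino end, and that step stayed within the scatter. Compound 4 is therefore expected to fall close to compound 3 and compound 1 alike, with no step beyond the scatter: a 1.5-fold lower number from compound 1 to compound 4 (0.18 log units; within the scatter). The estimate for compound 4 in this assay is 1900 nM, with a range from 900 nM to 4000 nM.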

Compound 4, half-maximal inhibitory concentration: 5020 nM
Beside the measured number, compound 4's estimate is 2.6-fold (0.42 log units) below it; measured number outside the range, above it.
By their numbers in this assay, from the lowest: compounds 3, 2, 1 and 4 (each within the scatter of the next, the first and the last beyond it).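

In this assay, the group on the amide-type nitrogen now makes a readable difference: going to the shorter 2-(dimethylamino)ethyl chain gives a 2.7-fold higher number from compound 3 to compound 4 (0.43 log units; beyond the scatter) in a change confined to the chain length. Putting the same 2-(dimethylamino)ethyl group in place of 3-chlorophenyl gives a 2.6-fold higher number from compound 2 to compound 4 (0.42 log units; beyond the scatter) as a second modest step, whereas its exchange for 2-methoxyphenyl gives a 1.8-fold higher number from compound 1 to compound 4 (0.25 log units; within the scatter) and so leaves compound 4 inseparable from compound 1. The two dimethylamino chains therefore do not behave alike here, although this rests on a single pair of compounds, and nothing measured in this set accounts for the gap between them.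

A 4-(dimethylamino)butyl chain would show whether the number keeps the level of compound 3 as the chain grows longer, or whether compound 4 is a lone departure. Swapping the dimethylamino end of the 2-(dimethylamino)ethyl chain for a morpholine or a piperidine ring would show whether the outcome follows the chain length alone or also depends on the amine at its end.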